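The source may report more compounds than this note shows. Statements on the series, on what has been measured and on what is new or still open speak of the compounds shown alone.

In a functional assay on A549 cells (Homo sapiens) for inhibition, read by MTT assay, with a stated time of 48 h (on this read-out higher numbers stand for weaker inhibition and lower numbers for stronger inhibition), two related compounds have been measured so far. Compound 1 (`Brc1ccc2[nH]cc(C(c3c[nH]c4ccc(Br)cc34)C3CCCCC3)c2c1`) gives 5500 nM. Compound 2 (`O=[N+]([O-])c1ccc2[nH]cc(C(c3ccc(Cl)cc3)c3c[nH]c4ccc([N+](=O)[O-])cc34)c2c1`) gives > 100000 nM, which is a limit of the assay and not a number. Compound 2 thus stands at the limit of > 100000 nM in this assay, at which 1 of the 2 values shown sits, and no exact value is known for it.

Compound 3 (`CCCCCCCC(c1c[nH]c2ccc([N+](=O)[O-])cc12)c1c[nH]c2ccc([N+](=O)[O-])cc12`) has yet to be measured. It differs from compound 2 by a single change, heptyl in place of 4-chlorophenyl on a saturated chain carbon bound to two aromatic carbons. Within the data shown here, no measured pair shows this change alone, and compound 1 differs from compound 2 in more than one place. Among the measured compounds shown here, the only guide is that compound 3 has no aromatic ring on that carbon, like compound 1, and compound 1 gives 5500 nM. A moderate step towards lower numbers, meaning stronger inhibition, is therefore expected in this assay, although compound 3 may also stay at the limit. The estimated change is an at least 3.3-fold lower number from compound 2 to compound 3 (0.52 log units; beyond the scatter). The estimate for compound 3 is 30000 nM, with an expected range of 6000 nM to 100000 nM.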

Compound 3, half-maximal inhibitory concentration: 12500 nM
Estimate against measurement, compound 3: 2.4-fold (0.38 log units) above, and the stated range covers the measured number.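

Heptyl in place of 4-chlorophenyl on a saturated chain carbon bound to two aromatic carbons gives, in this assay, an at least 8.0-fold lower number from compound 2 to compound 3 (0.90 log units; beyond the scatter). Among these compounds, this is the first direct reading at this position: with the rest of the shared core held fixed, the change moves the read-out from a limit to a number, so what sits on this carbon matters. The size of the step is only a lower bound because compound 2 stands at a limit of the assay and not at a number: the limit of > 100000 nM in this assay, at which 1 of the 3 values shown sits.

The compounds shown leave open whether the lower number comes from the heptyl chain as such or simply from the loss of the 4-chlorophenyl ring, and a shorter chain such as butyl, a longer chain such as decyl, or a heptyl chain ending in an amine would each bear on that question. As far as these compounds go, compound 1 differs from compound 3 in more than one place, so how the groups on the shared core and the group on this carbon each contribute remains open.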